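From chloro to methoxy on compound 3

The source may hold more compounds than are shown below. What is called first, only, known or untested is meant among the compounds shown, and "the series" means these compounds.

- compound 1 `Cc1ccc(N2CCN(CC(=O)Nc3ccc(-c4nc5ccccc5s4)cc3)CC2)cc1`: 200 nM
- compound 2 `O=C(CN1CCN(c2ccccc2F)CC1)Nc1ccc(-c2nc3ccccc3s2)cc1`: 200 nM
- compound 3 `Clc1cccc(-n2cc(CNc3ccc(-c4nc5ccccc5s4)cc3)nn2)c1`: 200 nM

All three compounds were tested in a functional assay on HeLa cells (Homo sapiens) for inhibition (on this read-out lower numbers stand for stronger inhibition of growth and higher numbers for weaker inhibition of growth), and read the same at the digits reported. Compound 3 stands level with compounds 1 and 2, although the part attached to the shared core in compound 3 differs from that in the other two.

The next compound, compound 4 `COc1cccc(-n2cc(CNc3ccc(-c4nc5ccccc5s4)cc3)nn2)c1`, keeps all of compound 3 except one group. Methoxy takes the place of chloro on an aromatic carbon, meta to a large group, turning 3-chlorophenyl into 3-methoxyphenyl: methoxy in place of chloro on an aromatic carbon gives the count.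

Among the compounds with values here, only one measured step offers any guide: no change at the digits printed from compound 1 to compound 2 (within the scatter). There, one substituted phenyl group replaces another, and the read-out does not move beyond the scatter. Within the data shown here, this evidence is indirect, since that step was made on a different framework and no measured pair exchanges chloro for methoxy. With nothing pointing either way, the expected result is no change at the digits printed from compound 3 to compound 4 (within the scatter), with no direction favoured in this assay. For compound 4 the estimated value is 200 nM, with an expected range of 90 nM to 450 nM.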

Compound 4, concentration for 50% growth inhibition: 200 nM
The estimate for compound 4 equals the measured number at the digits printed; the range from low to high includes it.
By their numbers in this assay, from the lowest: compounds 1, 2, 3 and 4 (each within the scatter of the next).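

In this assay, methoxy in place of chloro on an aromatic carbon, meta to a large group, gives no change at the digits printed from compound 3 to compound 4 (within the scatter). Within the data shown here, this is the first direct reading at this position: the only earlier step, no change at the digits printed from compound 1 to compound 2 (within the scatter), changed a substituted phenyl group on a different framework, whereas here a group counted as a hydrogen-bond acceptor replaces one that is not, and the growth-inhibition value does not move beyond the scatter. No measurement bears on this result or offers a reason for it.

The compounds shown leave open whether this position stays as flat for other kinds of group, since an amine, a carboxylic acid or a longer chain on the same aromatic carbon could move the value or could leave it where it is. Also open, going by these compounds, is whether the exchange of chloro for methoxy would read the same on the framework of compounds 1 and 2, as this single pair speaks only for the framework of compound 3.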